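Bromo for methoxycarbonyl: outlook for compound 3

A few compounds are considered here, and "the series" means these few. Any claim that something is new, unique, unknown or untested is made for them only; others in the source may bear on it.

Compound 2 `COC(=O)c1ccc(N2C(=O)C=CC2OCC(F)(F)F)cc1` gives 8170 nM in a functional assay on A549 cells (Homo sapiens) for inhibition; on this read-out higher numbers stand for weaker inhibition and lower numbers for stronger inhibition. Compound 1 `CCc1ccc(N2C(=O)C=CC2OCC(F)(F)F)cc1` gives 8090 nM in this assay. Among the compounds with values here, compound 2 sits alongside compound 1 in the numbers so far: the step of a 1.0-fold higher number from compound 1 to compound 2 (0.00 log units; within the scatter) is within the scatter, so neither compound stands apart from the other. Compound 3 `O=C1C=CC(OCC(F)(F)F)N1c1ccc(Br)cc1` is not yet measured; it differs from compound 2 by bromo in place of methoxycarbonyl on an aromatic carbon. Within the data shown here, no measured step swaps in a bromo group; the only step available, a 1.0-fold higher number from compound 1 to compound 2 (0.00 log units; within the scatter), shows ethyl and methoxycarbonyl on that aromatic carbon giving numbers that cannot be told apart. On that basis no shift beyond the scatter is expected for compound 3 in this assay, the estimated step being a 1.0-fold lower number from compound 2 to compound 3 (0.01 log units; within the scatter). Compound 3 is expected to give about 8000 nM, within a range from 3000 nM to 22000 nM.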

Compound 3, half-maximal inhibitory concentration: 6960 nM
Estimate against measurement, compound 3: 1.1-fold (0.06 log units) above; the range from low to high includes it.
By their numbers in this assay, from the lowest: compounds 3, 1 and 2 (each within the scatter of the next).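

In this assay, bromo on the aromatic carbon para to a large group gives a 1.2-fold lower number from compound 2 to compound 3 (0.07 log units; within the scatter) against methoxycarbonyl and a 1.2-fold lower number from compound 1 to compound 3 (0.07 log units; within the scatter) against ethyl. A single bromine atom can therefore replace the four heavy atoms of methoxycarbonyl, along with its hydrogen-bond acceptors and its double bond outside aromatic rings, and the number stays within the scatter; across compound 1, compound 2 and compound 3, this position has not yet separated any two groups. No measurement at hand explains why these three groups give numbers so close together.

Going by these compounds, whether an amine or a carboxylic acid on this aromatic carbon would move the number beyond the scatter remains open. Also open, on these data alone, is whether changes elsewhere on the shared core would do so.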